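The compounds below may be only part of what the source reports. "The series", "measured", "known", "first", "only" and "open" are said of these compounds alone.

Working notes on the series. Compound 1 `O=C(NCc1cc(Cl)ccc1-n1cnnn1)[C@@H]1CC=NN1C(=O)[C@H](O)c1ccccc1` and compound 2 `O=C(NCc1cc(Cl)ccc1-n1cnnn1)[C@@H]1CC=NN1C(=O)[C@H](O)Cc1ccccc1` share one core, while compound 3 `O=C(NCc1cc(Cl)ccc1-n1cnnn1)[C@@H]1[C@@H]2C[C@@H]2CN1C(=O)[C@H](O)Cc1ccccc1` and the not yet measured compound 4 `O=C(NCc1cc(Cl)ccc1-n1cnnn1)[C@@H]1[C@@H]2C[C@@H]2CN1C(=O)[C@H](O)c1ccccc1` share another; the difference between the two cores is not broken down here.

In an ADME assay on liver for metabolic stability, with Liver microsome (Homo sapiens) as the target, read by LC-MS, using microsomes (on this read-out lower numbers stand for slow clearance and higher numbers for fast clearance), compound 1 gives < 12 mL.min-1.g-1, which is a limit of the assay and not a number. In this assay compound 2 also gives < 12 mL.min-1.g-1, again a limit of the assay rather than a number. The step that the two limits leave unreadable from compound 2 to compound 1 is therefore not readable, since what is known of both compounds is the limit of < 12 mL.min-1.g-1 in this assay, at which 2 of the 3 values shown sit. The change behind that step is phenyl in place of benzyl on a saturated chain carbon bound to a carbonyl carbon and an oxygen on a saturated carbon.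

In this assay, going by the values given here, compound 3 gives 74 mL.min-1.g-1, the only actual number among the three values so far.

Compound 4 differs from compound 3 by phenyl in place of benzyl on a saturated chain carbon bound to a carbonyl carbon and an oxygen on a saturated carbon, the same change as from compound 2 to compound 1, made on the other core. The earlier instance of this change gives no size that could be carried over, as both of its ends sit at a limit. The expectation for compound 4 therefore leans on compound 3 alone, whose value of 74 mL.min-1.g-1 is the only anchor on this core. Compound 4 is estimated at 55 mL.min-1.g-1 in this assay, with a likely range from 20 mL.min-1.g-1 to 150 mL.min-1.g-1. The expected step of a 1.3-fold lower number from compound 3 to compound 4 (0.13 log units; within the scatter) is thus small and within the usual scatter, an expectation that rests on compound 3 at 74 mL.min-1.g-1 and on the absence of any readable size for this change elsewhere in the set.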

Compound 4, intrinsic clearance in microsomes: < 15 mL.min-1.g-1
Compound 4: a limit, no number (the forecaster's own chance of this, stated with the estimate: 15%); at least 3.6-fold (0.56 log units) between middle value and limit.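

In this assay, phenyl in place of benzyl on the core of compound 3 gives an at least 4.9-fold lower number from compound 3 to compound 4 (0.69 log units; beyond the scatter), so on this core the change moves the read-out towards slow clearance by more than the usual scatter. From the compounds shown here alone, the full size of that step stays unknown because compound 4 sits at a limit of the assay and not at a number: the limit of < 15 mL.min-1.g-1 in this assay, at which 1 of the 4 values shown sits. Whether the change carries from one core to the other cannot be judged, because the step from compound 2 to compound 1 cannot be read, with both compounds at the same limit of the assay: the limit of < 12 mL.min-1.g-1 in this assay, at which 2 of the 4 values shown sit.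

The compounds shown leave open how the read-out in this assay behaves on the core of compound 3 with anything other than benzyl or phenyl at this place, for instance a longer chain such as 3-phenylpropyl, or an amine or a carboxylic acid carried on the phenyl ring. They also leave open whether any such group would give a number on the core of compound 1, where a step in the size of this change could then be read and set against the one on the core of compound 3.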